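Thioether substituent swap on the shared core

The compounds below may be only part of what the source reports. "The series", "measured", "known", "first", "only" and "open" are said of these compounds alone.

Compound 3 `COCSc1nc(NCc2ccc(-c3ccccn3)cc2)c2[nH]nc(C(C)C)c2n1` stands second highest of the three numbers in a functional assay on HT cells (Homo sapiens) for antiproliferative activity, read by fluorescence, with a stated time of 72 h (a higher number here means a weaker inhibitor of growth, a lower number a stronger inhibitor of growth), where compound 3 gives 340 nM. Its nearest neighbour is compound 1 `CC(C)c1n[nH]c2c(NCc3ccc(-c4ccccn4)cc3)nc(SC(C)C(C)O)nc12`, for which 190 nM is recorded; the step of a 1.8-fold higher number from compound 1 to compound 3 (0.25 log units; within the scatter) lies within the scatter. Compound 2 `CC(C)c1n[nH]c2c(NCc3ccc(-c4ccccn4)cc3)nc(S)nc12`, with hydrogen on the sulfur, gives 2760 nM, and the step of an 8.1-fold lower number from compound 2 to compound 3 (0.91 log units; beyond the scatter) is the clearer move in the set, matched by a 15-fold higher number from compound 1 to compound 2 (1.16 log units; beyond the scatter) in the opposite direction.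

Compound 4 `CSCCSc1nc(NCc2ccc(-c3ccccn3)cc2)c2[nH]nc(C(C)C)c2n1` differs from compound 3 as follows: (methylsulfanyl)methyl in place of methoxy on a saturated chain carbon bound to a sulfur. Two kinds of step bear on this. an 8.1-fold lower number from compound 2 to compound 3 (0.91 log units; beyond the scatter) and a 15-fold higher number from compound 1 to compound 2 (1.16 log units; beyond the scatter) show that a carbon chain on the sulfur in place of hydrogen goes with a markedly lower number, while a 1.8-fold higher number from compound 1 to compound 3 (0.25 log units; within the scatter) shows that exchanging one such chain for another stays within the scatter. Because a 1.8-fold higher number from compound 1 to compound 3 (0.25 log units; within the scatter) is within the scatter, no step beyond the scatter is expected for compound 4 in this assay, the expected step being a 1.1-fold lower number from compound 3 to compound 4 (0.05 log units; within the scatter). Compound 4 is estimated at 300 nM, with a range from 120 nM to 750 nM.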

Compound 4, concentration for 50% growth inhibition: 975 nM
Compound 4: middle estimate off by 3.3-fold (0.51 log units), on the low side; the whole stated range lies below it.
By their numbers in this assay, from the lowest: compounds 1 and 3 (each within the scatter of the next); then compound 4; then compound 2.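

In this assay, exchanging one chain on the sulfur for another is not always neutral: the steps (a 2.9-fold higher number from compound 3 to compound 4 (0.46 log units; beyond the scatter)) and (a 5.1-fold higher number from compound 1 to compound 4 (0.71 log units; beyond the scatter)) both lie beyond the scatter, whereas compound 1 and compound 3 stayed within it. The 2-(methylsulfanyl)ethyl chain still gives a lower number than hydrogen on the sulfur (a 2.8-fold lower number from compound 2 to compound 4 (0.45 log units; beyond the scatter)), though this step is smaller than the one for methoxymethyl (an 8.1-fold lower number from compound 2 to compound 3 (0.91 log units; beyond the scatter)). The identity of the chain on the sulfur therefore matters here, not just its presence.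

No measurement shown accounts for the higher number of compound 4. Going by these compounds, whether chain length or the sulfur within the chain goes with this step remains open, as does the outcome for a 2-methoxyethyl chain or for a chain ending in an amine or a carboxylic acid.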